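The source may report more compounds than this note shows. Statements on the series, on what has been measured and on what is new or still open speak of the compounds shown alone.

Compound 1 `O=C(NCCNS(=O)(=O)c1ccc(-c2ccccc2Oc2ccc([N+](=O)[O-])c([N+](=O)[O-])c2)s1)Nc1ccc([N+](=O)[O-])cc1` – 340 nM
Compound 2 `COc1ccc(NC(=O)NCCNS(=O)(=O)c2ccc(-c3ccccc3OCc3cccc(O)c3)s2)cc1` – > 20000 nM (a limit)

In a functional assay on HL-60 cells (Homo sapiens) for inhibition, read by CCK-8 assay, with a stated time of 48 h (a lower number here means a stronger inhibitor, a higher number a weaker inhibitor), compound 2 gives > 20000 nM as a limit of the assay, not a number. Its position therefore marks only the end of the measurable range (the limit of > 20000 nM in this assay, at which 1 of the 2 values shown sits). Compound 3 (`COc1ccc(NC(=O)NCCNS(=O)(=O)c2ccc(-c3ccccc3Oc3ccc([N+](=O)[O-])c([N+](=O)[O-])c3)s2)cc1`) keeps the rest of compound 2 and carries 3,4-dinitrophenyl in place of 3-hydroxybenzyl on an oxygen on an aromatic ring. Compound 1 also carries 3,4-dinitrophenyl on such an oxygen and gives 340 nM in this assay, which is the basis for expecting a clear gain. The estimated step of an at least 33-fold lower number from compound 2 to compound 3 (1.52 log units; beyond the scatter) is large, toward stronger inhibition and well beyond the scatter. Among the compounds with values here, with only two measured compounds, the range stays wide. Compound 3 is expected at 600 nM (estimated range 150 nM to 3500 nM).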

Compound 3, half-maximal inhibitory concentration: 5400 nM
For compound 3 the middle estimate is 9.0-fold (0.95 log units) below the measured one; measured number outside the range, above it.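

In this assay, on these data alone, 3,4-dinitrophenyl in place of 3-hydroxybenzyl on an oxygen on an aromatic ring now gives a directly readable gain, an at least 3.7-fold lower number from compound 2 to compound 3 (0.56 log units; beyond the scatter), though its full size stays unknown. Compound 2 stands at a limit of the assay, not at a number: the limit of > 20000 nM in this assay, at which 1 of the 3 values shown sits. The second pair shows that 3,4-dinitrophenyl alone does not set the potency of compound 1, since methoxy in place of nitro on an aromatic carbon gives a 16-fold higher number from compound 1 to compound 3 (1.20 log units; beyond the scatter), so the series responds to changes in both places.

Open, as far as these compounds go, is whether the gain from 3,4-dinitrophenyl holds when nitro rather than methoxy sits on that aromatic carbon. Also open, from the compounds shown here alone, is how an amine or a carboxylic acid on that carbon would compare with nitro and methoxy in this assay.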